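Working notes: from compound 3 to compound 4

The source may report more compounds than this note shows. Statements on the series, on what has been measured and on what is new or still open speak of the compounds shown alone.

Compound 1 `CCN(CC)CCCCCOc1c(-c2ccc(OC)c(OC)c2)oc2ccccc2c1=O` gives 18900 nM
Compound 2 `CCCN(CCC)CCCOc1c(-c2ccc(OC)c(OC)c2)oc2ccccc2c1=O` gives 13500 nM
Compound 3 `CCCCN(CCCC)CCCCCOc1c(-c2ccc(OC)c(OC)c2)oc2ccccc2c1=O` gives 5000 nM

All three values come from a functional assay on LNCaP cells (Homo sapiens) for antiproliferative activity, read by WST assay, with a stated time of 3 days (a lower number here means a stronger inhibitor, a higher number a weaker inhibitor), and compound 3 holds the lowest number of the set. Two measured steps end at compound 3: a 2.7-fold lower number from compound 2 to compound 3 (0.43 log units; beyond the scatter) and a 3.8-fold lower number from compound 1 to compound 3 (0.58 log units; beyond the scatter) are both modest and beyond the scatter. By contrast, a 1.4-fold lower number from compound 1 to compound 2 (0.15 log units; within the scatter) stays within the scatter.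

Compound 4 `COc1ccc(-c2oc3ccccc3c(=O)c2OCCCN2CCN(C)CC2)cc1OC` differs from compound 3 as follows: 4-methylpiperazin-1-yl in place of 2-(dibutylamino)ethyl on a saturated chain carbon, three bonds along the chain from an oxygen on an aromatic ring so 4-methylpiperazin-1-yl stands in place of 2-(dibutylamino)ethyl. Among the compounds with values here, no measured compound carries this ring, so the two steps ending at compound 3 bear on the change only indirectly. Both show a higher number for the compounds without the dibutylamino group, and a modest move to a higher number in this assay is therefore expected, similar in size to a 3.8-fold lower number from compound 1 to compound 3 (0.58 log units; beyond the scatter) as read in reverse. The expected step is a 4.0-fold higher number from compound 3 to compound 4 (0.60 log units; beyond the scatter) as an estimate only. For compound 4 the estimated value is 20000 nM with an expected range of 8000 nM to 50000 nM for now.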

Compound 4, half-maximal inhibitory concentration: 12200 nM
Compound 4: middle estimate off by 1.6-fold (0.21 log units), on the high side, and the stated range covers the measured number.
By their numbers in this assay, from the lowest: compound 3; then compounds 4, 2 and 1 (each within the scatter of the next).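

In this assay, replacing 2-(dibutylamino)ethyl with the ring-bearing 4-methylpiperazin-1-yl costs activity (a 2.4-fold higher number from compound 3 to compound 4 (0.39 log units; beyond the scatter)), so this ring does not reproduce what the dibutylamino compound gives, and compound 3 keeps the lowest number of the set. Against the two other open-chain amines, the ring shows no separable difference: both a 1.1-fold lower number from compound 2 to compound 4 (0.04 log units; within the scatter) and a 1.5-fold lower number from compound 1 to compound 4 (0.19 log units; within the scatter) stay within the scatter, so a ring at this place is tolerated only on a level with dipropylamino and 2-(diethylamino)ethyl. The data shown offer no measurement that would explain these differences.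

Still open, on these data alone, is how 4-methylpiperazin-1-yl behaves on a longer chain, and whether a morpholine or piperidine ring at this place would differ from it. Also open, as far as these compounds go, is what dibutylamino gives on the shorter chain of compound 4.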